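Nitro for bromo on a flat series of three

The source may report more compounds than this note shows. Statements on the series, on what has been measured and on what is new or still open speak of the compounds shown alone.

Measured so far:
compound 1 `O=C(/C(=C\c1ccc(O)cc1)SCc1ccc(Cl)cc1)c1ccc(Br)cc1`, 10000 nM
compound 2 `CN(C)c1ccc(/C=C(/SCc2ccc(Cl)cc2)C(=O)c2ccc(Br)cc2)cc1`, 10000 nM
compound 3 `O=C(/C(=C\c1cccc(Cl)c1Cl)SCc1ccc(Cl)cc1)c1ccc(Br)cc1`, 10000 nM

In a functional assay on DU-145 cells (Homo sapiens) for inhibition, read by trypan blue exclusion, with a stated time of 96 h (a higher number here means a weaker inhibitor of growth, a lower number a stronger inhibitor of growth), compound 2 gives 10000 nM, level with compound 1 and compound 3 at the digits shown. The three measured steps all change the ring on the double-bonded chain carbon: no change at the digits printed from compound 1 to compound 2 (within the scatter), no change at the digits printed from compound 1 to compound 3 (within the scatter), and no change at the digits printed from compound 2 to compound 3 (within the scatter). Every one of them stays within the scatter.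

Compound 4 `CN(C)c1ccc(/C=C(/SCc2ccc(Cl)cc2)C(=O)c2ccc([N+](=O)[O-])cc2)cc1` differs from compound 2 at the other end of the core: nitro in place of bromo on an aromatic carbon. Among the measured compounds shown here, no measured step touches this aromatic carbon, so the three flat steps bear on it only indirectly, by showing that this assay has so far not moved for any change. On that basis a step within the scatter is expected, with no direction favoured, which is written as no change at the digits printed from compound 2 to compound 4 (within the scatter). Compound 4 is therefore estimated at 10000 nM in this assay, with a range from 4000 nM to 25000 nM.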

Compound 4, concentration for 50% growth inhibition: > 100000 nM
Compound 4: only a limit was reported; the forecaster's own chance of this, stated with the estimate: 35%; middle value at least 10-fold (1.00 log units) from the limit.
By their numbers in this assay, from the lowest: compounds 1, 2 and 3 (each within the scatter of the next). At a limit, above all of these: compound 4.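

In this assay, among the compounds shown here, the aromatic carbon carrying the bromo group is the first place where a change registers: nitro in place of bromo gives an at least 10-fold higher number from compound 2 to compound 4 (1.00 log units; beyond the scatter). The earlier steps shown here, all on the ring at the other end of the core, showed no response, so they could not show that this assay can move for these compounds, or that the direction here is towards weaker inhibition of growth. For compound 4 the reading is a limit and not a number, so the true size of the step stays unknown: the limit of > 100000 nM in this assay, at which 1 of the 4 values shown sits.

The compounds shown leave open whether bromine itself matters at this position, or whether chloro, methoxy, an amine or a carboxylic acid there would stay level with compound 2 or move the number either way. They also leave open whether nitro has the same effect when the hydroxy group of compound 1 or the 2,3-dichlorophenyl ring of compound 3 is present.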